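The source may hold more compounds than are shown below. What is called first, only, known or untested is meant among the compounds shown, and "the series" means these compounds.

Three members of the series have so far been run in a functional assay on BJAB cells (Homo sapiens) for antiproliferative activity, with a stated time of 4 days; on this read-out lower numbers stand for an effect already at smaller amounts and higher numbers for an effect only at larger amounts of compound. Compound 1 `COc1ccc(-c2c(C)nn(-c3nc(-c4ccc(Cl)c(Cl)c4)c(SC(C)C)s3)c2C(=O)O)cc1` gives 2100 nM, compound 2 `Cc1ccccc1-c1c(C)nn(-c2nc(-c3ccc(Cl)c(Cl)c3)c(SC(C)C)s2)c1C(=O)O` gives 5500 nM, and compound 3 `Cc1c(-c2cc(Cl)cc(Cl)c2)c(C(=O)O)nn1-c1nc(-c2cc(Cl)cc(Cl)c2)c(SC(C)C)s1` gives 2000 nM. Among the compounds with values here, compound 2 therefore carries the highest number of the three; the only single-change step recorded is a 2.6-fold higher number from compound 1 to compound 2 (0.42 log units; beyond the scatter), a modest move, while compound 3 differs from compound 2 in two places and is not linked by a step. Compound 4 `Cc1nn(-c2nc(-c3ccc(Cl)c(Cl)c3)c(SC(C)C)s2)c(C(=O)O)c1-c1cc(C#N)cc(C(F)(F)F)c1` is the next case: 3-cyano-5-(trifluoromethyl)phenyl in place of 2-methylphenyl on an aromatic carbon. Only a 2.6-fold higher number from compound 1 to compound 2 (0.42 log units; beyond the scatter) bears on this position, and it shows that an aryl exchange there shifts this assay modestly. For compound 4 a modest fall in number is expected, a 2.2-fold lower number from compound 2 to compound 4 (0.34 log units; beyond the scatter). The estimate for compound 4 is 2500 nM, with a range from 900 nM to 7000 nM.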

Compound 4, half-maximal effective concentration: 3600 nM
Compound 4: the middle estimate sits 1.4-fold (0.16 log units) below what was measured, and the stated range covers the measured number.
By their numbers in this assay, from the lowest: compounds 3, 1, 4 and 2 (each within the scatter of the next, the first and the last beyond it).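

In this assay, 3-cyano-5-(trifluoromethyl)phenyl is tolerated on this aromatic carbon, with both new steps within the scatter: (a 1.5-fold lower number from compound 2 to compound 4 (0.18 log units; within the scatter)) and (a 1.7-fold higher number from compound 1 to compound 4 (0.23 log units; within the scatter)). Thus 12 heavy atoms in place of 7, with a nitrile bringing a hydrogen-bond acceptor, leave the number unresolved from those of the two other aryl groups. No measurement available here explains this tolerance.

Open, as far as these compounds go, is whether this carbon keeps such numbers with a non-aromatic group, such as an aminomethyl group or a longer alkyl chain. Also open, from the compounds shown here alone, is the effect of a primary amide in place of the carboxy group.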